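This account rests on a few compounds, and the source may have more. Where it says the series, first, only, none or still open, it means among the compounds named here.

Measured so far:
- compound 1, `O=C(/C=C/c1cn(-c2ccccc2)nc1-c1ccncc1)c1ccccc1`: 3100 nM
- compound 2, `COc1cc(C(=O)/C=C/c2cn(-c3ccccc3)nc2-c2ccncc2)cc(OC)c1OC`: 300 nM

Both numbers come from a functional assay on HCT-116 cells (Homo sapiens) for inhibition, read by sulforhodamine B assay, with a stated time of 72 h; on this read-out lower numbers stand for stronger inhibition and higher numbers for weaker inhibition. Compound 1 gives 3100 nM there, compound 2 gives 300 nM. Compound 2 therefore stands at the lowest of the two numbers; its nearest neighbour is compound 1, whose number is higher by a gap well beyond the usual scatter. The two values show that the ring carrying three methoxy groups sits far lower than the bare ring.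

Compound 3, `COc1ccc(C(=O)/C=C/c2cn(-c3ccccc3)nc2-c2ccncc2)cc1OC`, is not yet measured in this assay. It differs from compound 2 by hydrogen in place of methoxy on an aromatic carbon. Among the measured compounds shown here, no measured pair shows this single change, so the expectation rests on the two values above: taking one methoxy away moves compound 3 part of the way from compound 2 toward the bare ring of compound 1. A step toward a higher number, beyond the scatter, is expected, while the estimate for compound 3 remains well short of compound 1.

Compound 3 is expected at 900 nM, with a range from 300 nM to 2700 nM. The expected step of a 3.0-fold higher number from compound 2 to compound 3 (0.48 log units; beyond the scatter) is a moderate loss.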

Compound 3, half-maximal inhibitory concentration: 1200 nM
Estimate against measurement, compound 3: 1.3-fold (0.12 log units) below; low and high end bracket the measured number.
By their numbers in this assay, from the lowest: compound 2; then compound 3; then compound 1.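

In this assay, hydrogen in place of methoxy on the aromatic carbon, ortho to a methoxy group and meta to a large group, gives a 4.0-fold higher number from compound 2 to compound 3 (0.60 log units; beyond the scatter) and so isolates this one position: a methoxy group there counts on its own, and the third methoxy group is not redundant with the two that remain. The other single change, 3,4-dimethoxyphenyl in place of phenyl on the carbonyl carbon, gives a 2.6-fold lower number from compound 1 to compound 3 (0.41 log units; beyond the scatter) and shows that the two remaining methoxy groups still hold a gain over the bare phenyl, so the ordering among these compounds is spread over more than one substituent rather than resting on the third methoxy group alone. Nothing available gives a reason for either step.

As far as these compounds go, whether the oxygen or the methyl of the methoxy group matters at this position stays open, as a hydroxy group, an ethoxy group, fluorine or an amine at the same carbon would be needed to separate these. Also open, from the compounds shown here alone, is whether each methoxy group contributes alone, which would take a phenyl ring bearing a single methoxy group on the shared core.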